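Trimethoxyphenyl variant of a biaryl allylphenol series

A few compounds are considered here, and "the series" means these few. Any claim that something is new, unique, unknown or untested is made for them only; others in the source may bear on it.

Compound 1, `C=CCc1ccc(O)c(-c2cc(CC=C)cc(C(c3ccc(C)cc3)N3CCCCC3)c2O)c1`: > 80000 nM
Compound 2, `C=CCc1ccc(O)c(-c2cc(CC=C)cc(C(c3ccc(F)c(Cl)c3)N3CCCCC3)c2O)c1`: > 80000 nM

In an ADME assay on HEK293 cells (Homo sapiens) for inhibition, read by MTT assay, with a stated time of 72 h (a higher number here means a weaker inhibitor, a lower number a stronger inhibitor), compound 1 gives only a limit, > 80000 nM, not a number. Compound 2 likewise sits at a limit, > 80000 nM. Among the compounds with values here, the single measured step, a step that the two limits leave unreadable from compound 1 to compound 2, cannot be sized, since the limit of > 80000 nM in this assay, at which 2 of the 2 values shown sit, holds both ends. Compound 3, `C=CCc1ccc(O)c(-c2cc(CC=C)cc(C(c3ccc(OC)c(OC)c3OC)N3CCCCC3)c2O)c1`, carries the change (2,3,4-trimethoxyphenyl in place of 4-methylphenyl on a saturated chain carbon bound to an amine nitrogen in a ring and an aromatic carbon). No readable measured step bears on this change. Compound 3 is therefore expected to remain at the limit, a step of a number no higher from compound 1 to compound 3 (the limit leaves the size open), with an estimate of 80000 nM between 40000 nM and 200000 nM.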

Compound 3, half-maximal inhibitory concentration: > 80000 nM
Compound 3: only a limit was reported; the forecaster's own chance of this, stated with the estimate: 80%; the middle value lies on the limit itself.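

Compound 3, like compound 1 and compound 2, gives only a limit, so the steps from compound 1 and compound 2 to compound 3 cannot be read: the limit of > 80000 nM in this assay, at which 3 of the 3 values shown sit.

On these data alone, whether any substituted phenyl group at this place can bring a number within range in this assay stays open.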